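The source may report more compounds than this note shows. Statements on the series, on what has been measured and on what is new or still open speak of the compounds shown alone.

Measured in a functional assay on P388 cells (Mus musculus) for inhibition, read by MTT assay, with a stated time of 72 h; a higher number here means a weaker inhibitor, a lower number a stronger inhibitor:
compound 1, `Cc1cccc(NC(=O)c2ccc(/N=N\c3c[nH]c4ccccc34)cc2)c1C`: 51600 nM
compound 2, `O=C(Nc1ccccc1Cl)c1ccc(/N=N\c2c[nH]c3ccccc23)cc1`: "not active" (no number reported)
compound 3, `O=C(Nc1ccccc1F)c1ccc(/N=N\c2c[nH]c3ccccc23)cc1`: 106000 nM

Compound 3 holds the higher of the two numbers in this assay; compound 1 lies nearest to it, and compound 2 returned no number. Among the measured compounds shown here, the single measured step, a 2.1-fold higher number from compound 1 to compound 3 (0.31 log units; beyond the scatter), also exchanges the ring on the amide-type nitrogen and was modest. Compound 4, `O=C(Nc1cccc([N+](=O)[O-])c1)c1ccc(/N=N\c2c[nH]c3ccccc23)cc1`, differs from compound 3 by 3-nitrophenyl in place of 2-fluorophenyl on an amide-type nitrogen. For the measured compounds named here, no measured pair introduces a 3-nitrophenyl, so the direction of this step is open; the outcome for compound 2 shows that a number may not be obtained at all. The expected step is a 1.1-fold lower number from compound 3 to compound 4 (0.03 log units; within the scatter), near no change beyond the scatter. Compound 4 is estimated at 100000 nM, range 40000 nM to 300000 nM.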

Compound 4, half-maximal inhibitory concentration: 51900 nM
Estimate against measurement, compound 4: 1.9-fold (0.28 log units) above; low and high end bracket the measured number.
By their numbers in this assay, from the lowest: compounds 1 and 4 (each within the scatter of the next); then compound 3.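

In this assay, a 3-nitrophenyl on the amide-type nitrogen gives a modest gain over 2-fluorophenyl (a 2.0-fold lower number from compound 3 to compound 4 (0.31 log units; beyond the scatter)). It stands level with 2,3-dimethylphenyl (a 1.0-fold higher number from compound 1 to compound 4 (0.00 log units; within the scatter)), so this position accepts the first substituted ring here that carries hydrogen-bond acceptors, without a change from compound 1. No evidence at hand bears on the cause of either result.

On these data alone, whether a non-aromatic group on this nitrogen, such as an amine, a carboxylic acid or a longer chain, gives a number at all remains open. Also open, as far as these compounds go, is what separates compound 2, which returned no number, from compound 3.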